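A few compounds are considered here, and "the series" means these few. Any claim that something is new, unique, unknown or untested is made for them only; others in the source may bear on it.

Series notes. Three compounds are recorded against a functional assay on CWR22R cells (Homo sapiens) for antiproliferative activity, read by CCK-8 assay, with a stated time of 6 days; on this read-out higher numbers stand for weaker inhibition and lower numbers for stronger inhibition. Compound 1 `CCN(c1cccc(-c2ccccc2)c1)c1ccc(C#N)c(Cl)c1` gives "not determined" (no result reported) there, and compound 3 `N#Cc1ccc(N2CCc3cc(-c4cncnc4)ccc3C2)cc1C(F)(F)F` likewise gives "not determined" (no result reported), so neither supplies a number. Within the data shown here, compound 2 `CCN(c1ccc(C#N)c(Cl)c1)c1cc(-c2ccccc2)ccc1C` is the only entry with a reading, and that reading is a limit of this assay, not a number: compound 2 stands at > 30000 nM. The entry the limit of > 30000 nM in this assay, at which 1 of the 3 values shown sits, records the same point. Among the measured compounds shown here, no pair of measured compounds differing in one place is available, so there is no measured step to lean on.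

Compound 4 `CCN(c1ccc(C#N)c(Cl)c1)c1cc(-c2cccnc2)ccc1C` differs from compound 2 by pyridin-3-yl in place of phenyl on an aromatic carbon. The step in this assay is expected to be none beyond the scatter, the estimate being a number no higher from compound 2 to compound 4 (the limit leaves the size open). Compound 4 is accordingly estimated at 30000 nM, with an expected range from 8000 nM to 100000 nM. A further limit-only reading is taken as the most likely outcome for compound 4.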

Compound 4, half-maximal inhibitory concentration: 2000 nM
Beside the measured number, compound 4's estimate is 15-fold (1.18 log units) above it; measured number below the stated range.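

This position, on an aromatic carbon meta to a large group and para to a methyl group, responds strongly to the ring placed on it: pyridin-3-yl in place of phenyl gives an at least 15-fold lower number from compound 2 to compound 4 (1.17 log units; beyond the scatter) in this assay. The two groups have the same heavy-atom count and differ by a ring nitrogen and the hydrogen-bond acceptor counted with it, so an exchange this small is enough to give a reading that is a number. The reading for compound 2 is a limit, so the full size of the step stays open: the limit of > 30000 nM in this assay, at which 1 of the 4 values shown sits.

From the compounds shown here alone, whether the ring nitrogen must sit where it does in pyridin-3-yl remains open, and pyridin-4-yl at this position would test that. Also open, going by these compounds, is whether a phenyl carrying an amine or a carboxylic acid would match pyridin-3-yl here.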